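Meta-substituent variation on the shared core: thiazolyl replaces nitro

The source may report more compounds than this note shows. Statements on the series, on what has been measured and on what is new or still open speak of the compounds shown alone.

Compound 1 `O=C1NCCN(c2cccc(F)c2)N1` gives 19000 nM in an assay on RBL-1 cells for inhibition of Polyunsaturated fatty acid 5-lipoxygenase (Rattus norvegicus); on this read-out higher numbers stand for weaker inhibition and lower numbers for stronger inhibition; compound 2 `O=C1NCCN(c2cccc(Cl)c2)N1` gives 5300 nM, and compound 3 `O=C1NCCN(c2cccc([N+](=O)[O-])c2)N1` gives 49000 nM, the highest of the three numbers. Between the halogens the change is a 3.6-fold lower number from compound 1 to compound 2 (0.55 log units; beyond the scatter). Compound 4 `O=C1NCCN(c2cccc(-c3nccs3)c2)N1` differs from compound 3 by 1,3-thiazol-2-yl in place of nitro on an aromatic carbon. The two steps that touch the nitro group bear on this: a 2.6-fold higher number from compound 1 to compound 3 (0.41 log units; beyond the scatter) and a 9.2-fold higher number from compound 2 to compound 3 (0.97 log units; beyond the scatter), so leaving the nitro for either halogen lowered the number modestly. For the measured compounds named here, no measured step shows an aromatic ring at this position, so the direction rests on those two steps alone, and a modest fall in this assay is expected. Compound 4 is estimated at 15000 nM, within 4000 nM to 60000 nM. The expected step is a 3.3-fold lower number from compound 3 to compound 4 (0.51 log units; beyond the scatter).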

Compound 4, half-maximal inhibitory concentration: 35000 nM
Compound 4: middle estimate off by 2.3-fold (0.37 log units), on the low side, within the range that was stated.
By their numbers in this assay, from the lowest: compound 2; then compounds 1, 4 and 3 (each within the scatter of the next, the first and the last beyond it).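

The 1,3-thiazol-2-yl group, the first aromatic ring seen at this position, cannot be told apart from nitro (a 1.4-fold lower number from compound 3 to compound 4 (0.15 log units; within the scatter)) or from fluoro (a 1.8-fold higher number from compound 1 to compound 4 (0.27 log units; within the scatter)). Chloro stays clearly apart from it (a 6.6-fold higher number from compound 2 to compound 4 (0.82 log units; beyond the scatter)) and is the only one of the four groups apart from all three others. Nothing available explains this outcome.

Still open, as far as these compounds go, is whether a phenyl ring, a 2-pyridyl ring or a smaller group such as methyl or bromo at this position would match or pass compound 2.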